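The compounds below may be only part of what the source reports. "The series", "measured", "known", "first", "only" and "open" are said of these compounds alone.

Compound 1 `CCOC(=O)c1sc2ccccc2c1Nc1cc(OC)c(OC)c(OC)c1` gives 5490 nM in a functional assay on HL-60 cells (Homo sapiens) for cytotoxicity, read by MTT assay, with a stated time of 72 h; on this read-out lower numbers stand for stronger inhibition and higher numbers for weaker inhibition. Compound 2 `CCOC(=O)c1sc2cc(C)ccc2c1Nc1cc(OC)c(OC)c(OC)c1` gives 3.9 nM in this assay; the change from compound 1 is methyl in place of hydrogen on an aromatic carbon, and the step is a 1400-fold lower number from compound 1 to compound 2 (3.15 log units; beyond the scatter). Compound 3 `COC(=O)c1sc2ccccc2c1Nc1cc(OC)c(OC)c(OC)c1` gives 1540 nM in this assay; its core differs from that of compound 1 by hydrogen in place of methyl on a saturated chain carbon bound to an oxygen next to a carbonyl group, a step of a 3.6-fold lower number from compound 1 to compound 3 (0.55 log units; beyond the scatter). Compound 4 `COC(=O)c1sc2cccc(C)c2c1Nc1cc(OC)c(OC)c(OC)c1` is not yet measured; it differs from compound 3 by methyl in place of hydrogen on an aromatic carbon. This is the same kind of change as from compound 1 to compound 2, not the same: there the methyl stands meta to a fused ring and para to a fused ring, here ortho to a fused ring and meta to a fused ring. Going by the values given here, the only measured methyl step rests on a single pair at another place on the ring, so its size carries over only with reservation. Beside the measured 1400-fold lower number from compound 1 to compound 2 (3.15 log units; beyond the scatter), compound 4 is expected to give a smaller yet clear step, a 15-fold lower number from compound 3 to compound 4 (1.19 log units; beyond the scatter). Compound 4 is therefore estimated at 100 nM. For compound 4 the expected range runs from 5 nM to 3000 nM.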

Compound 4, half-maximal inhibitory concentration: 3390 nM
Beside the measured number, compound 4's estimate is 34-fold (1.53 log units) below it; measured number above the stated range.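

In this assay, methyl in place of hydrogen on an aromatic carbon gives a 2.2-fold higher number from compound 3 to compound 4 (0.34 log units; beyond the scatter), and the size and direction of this change do not carry over between the two cores: the same change on two cores in this assay, a 1400-fold lower number (3.15 log units; beyond the scatter) from compound 1 to compound 2 and a 2.2-fold higher number (0.34 log units; beyond the scatter) from compound 3 to compound 4, 3100-fold (3.49 log units) apart, beyond the scatter of two such steps

The two pairs differ in two respects at once, the ester chain and the place of the methyl, which in compound 4 stands ortho to a fused ring and meta to a fused ring, so the gap cannot be assigned to either respect alone. With a single pair on each core, the data show that the change cannot be transferred as a fixed increment, but they do not show what sets its size or direction.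

Still open, from the compounds shown here alone, is how the methyl behaves at the place it holds in compound 2 on the methyl ester core, and at the place it holds in compound 4 on the ethyl ester core, the two pairings that would separate ring place from ester chain. Also open, going by these compounds, is whether an ethyl, a methoxy or a chlorine at either ring place would follow the methyl.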